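Chloro for Trifluoromethyl: What Compound 3 Might Show

The source may report more compounds than this note shows. Statements on the series, on what has been measured and on what is new or still open speak of the compounds shown alone.

Of the compounds shown here, two sharing one core have so far been measured in an assay on CHO cells for displacement of a labelled ligand from prostaglandin E2 receptor EP4 subtype (Mus musculus), read by scintillation counting, with a stated time of 60 min; on this read-out higher numbers stand for weaker inhibition and lower numbers for stronger inhibition. Compound 1 `O=C(O)CCCSCCN1C(=O)OC[C@@H]1/C=C/[C@@H](O)Cc1cccc(C(F)(F)F)c1` gives 2 nM, the higher of the two numbers. Going by the values given here, compound 2 `CCCc1cccc(C[C@H](O)/C=C/[C@H]2CSC(=O)N2CCSCCCC(=O)O)c1` gives 0.98 nM, which lies beyond the scatter below the number of compound 1; the two structures differ in several places, however, so no single step connects them. Compound 3 `O=C(O)CCCSCCN1C(=O)OC[C@@H]1/C=C/[C@@H](O)Cc1cccc(Cl)c1` has not yet been measured. It differs from compound 1 in one place only: chloro in place of trifluoromethyl on an aromatic carbon. Among the compounds with values here, none of the measured compounds shows what this exchange does to the number, so the expectation rests on the closeness of the two structures alone. Compound 3 is expected to stay near compound 1, with a step of a 1.5-fold higher number from compound 1 to compound 3 (0.18 log units; within the scatter) that is expected to be within the scatter or at most a slight weakening. The estimate for compound 3 in this assay is 3 nM, between 1 nM and 10 nM.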

Compound 3, inhibition constant: 1.5 nM
Estimate against measurement, compound 3: 2.0-fold (0.30 log units) above; the measured number falls inside the stated range.
By their numbers in this assay, from the lowest: compounds 2, 3 and 1 (each within the scatter of the next, the first and the last beyond it).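

In this assay chloro in place of trifluoromethyl on an aromatic carbon gives a 1.3-fold lower number from compound 1 to compound 3 (0.12 log units; within the scatter) and is the only step shown between compounds that differ in one place. Compound 1 and compound 2 could not show what a change at this position alone does, whereas this pair shows that 3-(trifluoromethyl)phenyl and 3-chlorophenyl cannot be told apart on this read-out, although one heavy atom stands where four stood. No other measurement bears on why the two groups read alike.

Going by these compounds, whether a methoxy group, an amine or a carboxylic acid on this aromatic carbon would leave the number as close remains open. On these data alone, it is also open whether chloro on another carbon of the ring would do the same, and whether this exchange would read alike on the core of compound 2.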